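Rearranging the side chain on the shared core

The compounds below may be only part of what the source reports. "The series", "measured", "known", "first", "only" and "open" are said of these compounds alone.

Three compounds share one core and differ only in the branched chain carried on an aromatic nitrogen. Compound 1 `CCC(C)n1ccc2cc(/C(C)=C/C(=O)Nc3ccccc3OCCCC(=O)O)ccc21` gives 67 nM in an assay on Prostate gland for inhibition of steroid 5-alpha-reductase (Rattus norvegicus); a lower number here means a stronger inhibitor, a higher number a weaker inhibitor. Compound 2 `CCCC(C)n1ccc2cc(/C(C)=C/C(=O)Nc3ccccc3OCCCC(=O)O)ccc21` gives 7.8 nM, and compound 3 `CCCC(CC)n1ccc2cc(/C(C)=C/C(=O)Nc3ccccc3OCCCC(=O)O)ccc21` gives 9.3 nM. Compound 3 thus stands second highest of the three numbers; its nearest neighbour is compound 2, within the scatter, while its furthest is compound 1, beyond it. Compound 4 `CCCCC(C)n1ccc2cc(/C(C)=C/C(=O)Nc3ccccc3OCCCC(=O)O)ccc21` carries 1-methylpentyl in place of 1-ethylbutyl on an aromatic nitrogen; the two have the same atoms, joined differently. Going by the values given here, two measured steps bear on this: the change an 8.6-fold lower number from compound 1 to compound 2 (0.93 log units; beyond the scatter) and the change a 7.2-fold lower number from compound 1 to compound 3 (0.86 log units; beyond the scatter) both lowered the number, whereas the change a 1.2-fold higher number from compound 2 to compound 3 (0.08 log units; within the scatter) stayed within the scatter. Rearranging six chain carbons once more is therefore expected to leave this assay close to where compound 3 sits, with no step beyond the scatter, that is a 1.1-fold lower number from compound 3 to compound 4 (0.04 log units; within the scatter). Compound 4 is estimated at 8.5 nM, between 3 nM and 25 nM.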

Compound 4, half-maximal inhibitory concentration: 6 nM
Compound 4: the middle estimate sits 1.4-fold (0.15 log units) above what was measured; measured number inside the range.
By their numbers in this assay, from the lowest: compounds 4, 2 and 3 (each within the scatter of the next); then compound 1.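

In this assay, moving the branch so that 1-methylpentyl replaces 1-ethylbutyl on an aromatic nitrogen gives a 1.6-fold lower number from compound 3 to compound 4 (0.19 log units; within the scatter), so this rearrangement of the same six carbons does not separate the two compounds. Adding a methyl to the end of the chain in compound 2 likewise gives a 1.3-fold lower number from compound 2 to compound 4 (0.11 log units; within the scatter), whereas the comparison with the smaller chain of compound 1 gives an 11-fold lower number from compound 1 to compound 4 (1.05 log units; beyond the scatter), so compounds 2, 3 and 4 cannot be told apart, while all three stand clear of compound 1. Nothing measured here explains why these chains perform alike.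

The compounds shown leave open whether a chain longer than 1-methylpentyl would keep this level in the same place. They also leave open how a cyclohexyl ring, or a chain ending in an amine, would compare there.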